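Oral exposure: from compound 2 to compound 3

The compounds below may be only part of what the source reports. "The series", "measured", "known", "first", "only" and "open" are said of these compounds alone.

In an ADME assay on the whole organism (Rattus norvegicus, strain Sprague-Dawley) for pharmacokinetics, at a dose of 10 mg/kg by the oral route (on this read-out higher numbers stand for higher exposure at the dose given and lower numbers for lower exposure), compound 1 (`CCC(CC)N(CCN(C)C(=O)CCC(=O)O)Cc1cccc(C(=O)Nc2sc3c(c2C(=O)c2cnn(-c4ccc(Cl)c(C(F)(F)F)c4)c2)CCC(C)(C)C3)c1`) gives 2190 ng.h/mL and compound 2 (`CCC(CC)N(CCN(C)C(=O)CCC(=O)NCCOCCOCCOCCO)Cc1cccc(C(=O)Nc2sc3c(c2C(=O)c2cnn(-c4ccc(Cl)c(C(F)(F)F)c4)c2)CCC(C)(C)C3)c1`) gives 32.3 ng.h/mL as the lower of the two numbers, a gap beyond the usual scatter. Compound 3 (`CCC(CC)N(CCN(C)C(=O)CCC(=O)NC(C)(C)C(=O)NCCN(C)C)Cc1cccc(C(=O)Nc2sc3c(c2C(=O)c2cnn(-c4ccc(Cl)c(C(F)(F)F)c4)c2)CCC(C)(C)C3)c1`) keeps the shared core and differs from compound 2 only in the group on the amide-type nitrogen (a group of 11 heavy atoms (8 carbon, 2 nitrogen, 1 oxygen; no ring) in place of a group of 12 heavy atoms (8 carbon, 4 oxygen; no ring), on an amide-type nitrogen). For the measured compounds named here, no measured step covers a change of this kind, so the expectation is loose. Compound 2 at 32.3 ng.h/mL serves as the reference, as compound 3 also carries a substituted amide where compound 1 ends in a free acid. The expected step, estimated as a 1.9-fold higher number from compound 2 to compound 3 (0.27 log units; within the scatter) in this assay and upward, stays within the scatter. In this assay the expected value for compound 3 is 60 ng.h/mL ( range 12 ng.h/mL to 300 ng.h/mL).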

Compound 3, area under the concentration-time curve in the Rattus norvegicus assay: 15.3 ng.h/mL
Beside the measured number, compound 3's estimate is 3.9-fold (0.59 log units) above it; the measured number falls inside the stated range.
By their numbers in the Rattus norvegicus assay, from the lowest: compound 3; then compound 2; then compound 1.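

In the Rattus norvegicus assay, (1-((2-(dimethylamino)ethyl)carbamoyl)-1-methylethyl)amino in place of hydroxy on the carbonyl carbon gives a 140-fold lower number from compound 1 to compound 3 (2.16 log units; beyond the scatter), so a second, differently built amide chain also falls far short of the free acid. The exchange of amide chains gives a 2.1-fold lower number from compound 2 to compound 3 (0.32 log units; beyond the scatter), a modest step, so the chain with the dimethylamino end does not recover what the amide lost. In a physicochemical assay for solubility, in simulated intestinal fluid, at pH 6.6 (a higher number here means a more soluble compound, a lower number a less soluble compound), compound 2 gives 107 ug/mL and compound 3 gives 242 ug/mL. The same exchange thus runs opposite to exposure, and higher solubility does not come with higher oral exposure here: the measured solubility of compound 2, 107 ug/mL, and of compound 3, 242 ug/mL, a 2.3-fold higher number (0.35 log units; beyond the scatter)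

The two amide chains alone do not separate the effect of the amide link from that of the chain on it. A plain methyl group on the amide-type nitrogen, or a carboxylic acid at the end of a longer chain, would test this in the Rattus norvegicus assay.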